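From 6-methoxypyridin-3-yl to pyridin-2-yl

A few compounds are considered here, and "the series" means these few. Any claim that something is new, unique, unknown or untested is made for them only; others in the source may bear on it.

In a functional assay on HCT-116 cells (Homo sapiens) for antiproliferative activity, read by MTT assay, with a stated time of 24 h (on this read-out lower numbers stand for stronger inhibition and higher numbers for weaker inhibition), compound 3 `COc1ccc(/C=C/C(=O)c2ccc(OC)c3c2OC(C)(C)C=C3)cn1` gives > 10000 nM, which is a limit of the assay and not a number. Compound 1 `COc1cccc(/C=C/C(=O)c2ccc(OC)c3c2OC(C)(C)C=C3)c1` gives > 10000 nM, also a limit. Compound 2 `COc1ccc(/C=C/C(=O)c2ccc(OC)c3c2OC(C)(C)C=C3)c(F)c1` gives > 10000 nM, again a limit. The series therefore rests entirely on (the limit of > 10000 nM in this assay, at which 3 of the 3 values shown sit).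

The next structure, compound 4 `COc1ccc(C(=O)/C=C/c2ccccn2)c2c1C=CC(C)(C)O2`, carries pyridin-2-yl in place of 6-methoxypyridin-3-yl, on a double-bonded chain carbon bound to a double-bonded chain carbon: pyridin-2-yl in place of 6-methoxypyridin-3-yl on a double-bonded chain carbon bound to a double-bonded chain carbon.

The measured steps at this same place are a step that the two limits leave unreadable from compound 1 to compound 3, a step that the two limits leave unreadable from compound 2 to compound 3 and a step that the two limits leave unreadable from compound 1 to compound 2. None has a readable size, so they give no measured guide to the size or direction of this change. They show only that all three aryl variants tested there stayed at the limit, so another limit is the likeliest report. The expected change is a step that the limit leaves unreadable from compound 3 to compound 4, with no firm direction anticipated. For compound 4 the estimate is 12000 nM, with an expected range from 3000 nM to 30000 nM.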

Compound 4, half-maximal inhibitory concentration: 6630 nM
Compound 4: the middle estimate sits 1.8-fold (0.26 log units) above what was measured; low and high end bracket the measured number.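

In this assay, compound 4 is the first compound shown to give a number rather than a limit, so this place on the double-bonded chain carbon can register a change when pyridin-2-yl enters. Against the three limits, the result reads as an at least 1.5-fold lower number from compound 3 to compound 4 (0.17 log units; that floor lies within the scatter), an at least 1.5-fold lower number from compound 2 to compound 4 (0.17 log units; that floor lies within the scatter) and an at least 1.5-fold lower number from compound 1 to compound 4 (0.17 log units; that floor lies within the scatter). These steps are only floors, and their true size stays unknown because the comparison rests on limits: the limit of > 10000 nM in this assay, at which 3 of the 4 values shown sit.

The steps among compound 1, compound 2 and compound 3 still cannot be read, and the compounds shown do not separate the loss of the methoxy group from the change to pyridin-2-yl itself. They also leave open what an unsubstituted phenyl or a dimethylaminophenyl group would give at this place in this assay.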